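Changing the Aryl Group on a Growth Inhibitor

A few compounds are considered here, and "the series" means these few. Any claim that something is new, unique, unknown or untested is made for them only; others in the source may bear on it.

In a functional assay on RS4-11 cells (Homo sapiens) for inhibition, read by CCK-8 assay, with a stated time of 48 h, tested at 20 uM (on this read-out higher numbers stand for more inhibition of growth at the one concentration tested and lower numbers for less inhibition of growth), compound 1 `Cc1ccc(S(=O)(=O)Oc2cccc(/C=C(\C#N)C(=O)Nc3nnc(C)s3)c2)cc1` gives 28%, while compound 2 `COc1ccc(-c2nnc(NC(=O)/C(C#N)=C/c3cccc(OS(=O)(=O)c4ccc(C)cc4)c3)s2)cc1` gives 79%, the higher of the two numbers. Compound 3 `Cc1ccc(S(=O)(=O)Oc2cccc(/C=C(\C#N)C(=O)Nc3nnc(-c4ccccc4Cl)s3)c2)cc1` has not yet been measured. It keeps the shared core but carries 2-chlorophenyl in place of 4-methoxyphenyl on an aromatic carbon. For the measured compounds named here, only one measured step bears on this change: putting 4-methoxyphenyl in place of methyl gave a number 51 percentage points higher from compound 1 to compound 2 (beyond the scatter), a large step. Compound 3 still has an aromatic ring at this place, so it is expected to keep most of the gain seen in a number 51 percentage points higher from compound 1 to compound 2 (beyond the scatter). Going by the values given here, no measured pair compares two aromatic groups, so only a small fall in this assay, within the scatter, is expected. The expected step is a number 9 percentage points lower from compound 2 to compound 3 (within the scatter). For compound 3 the estimated value is 70%, with an expected range of 50% to 88%.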

Compound 3, percent growth inhibition at one concentration: 44%
Beside the measured number, compound 3's estimate is 26 percentage points above it; the measured number lies below the stated range.
By their numbers in this assay, from the lowest: compound 1; then compound 3; then compound 2.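

The aromatic ring alone does not decide the outcome at this position on the five-membered ring: in this assay, 2-chlorophenyl in place of 4-methoxyphenyl gives a number 35 percentage points lower from compound 2 to compound 3 (beyond the scatter), so the choice of aromatic group matters greatly. Compared with methyl, 2-chlorophenyl still gives a number 16 percentage points higher from compound 1 to compound 3 (beyond the scatter), so an aromatic group of this kind retains a modest advantage over the small group. Nothing measured here explains why the two aromatic groups differ.

The groups on compound 2 and compound 3 differ both in the atoms they carry and in where these sit on the phenyl ring, so those two changes cannot be separated. As far as these compounds go, it remains open how unsubstituted phenyl, 4-chlorophenyl or 2-methoxyphenyl would behave at this position, and whether a non-aromatic group such as an amine would match methyl or exceed it.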